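Swapping hydroxy for bromo on the aryl ring of compound 3

The compounds below may be only part of what the source reports. "The series", "measured", "known", "first", "only" and "open" are said of these compounds alone.

Three analogues built on one shared core were tested in a functional assay on MGC-803 cells (Homo sapiens) for antiproliferative activity, read by MTT assay, with a stated time of 72 h; a higher number here means a weaker inhibitor, a lower number a stronger inhibitor. Compound 1 `CCCSc1nc(N/N=C/c2ccc(Cl)cc2)c2nnn(Cc3ccccc3)c2n1` reaches only a limit of the assay, > 64000 nM (the limit of > 64000 nM in this assay, at which 1 of the 3 values shown sits). Compound 2 `CCCSc1nc(N/N=C/c2cccnc2)c2nnn(Cc3ccccc3)c2n1` gives 38100 nM in this assay. Compound 3 `CCCSc1nc(N/N=C(\C)c2ccc(O)cc2)c2nnn(Cc3ccccc3)c2n1` gives 16700 nM in this assay, the lowest of the two numbers, with compound 2 as the nearest. Both steps that exchange the group on the ring nitrogen moved the number down: an at least 3.8-fold lower number from compound 1 to compound 3 (0.58 log units; beyond the scatter) and a 2.3-fold lower number from compound 2 to compound 3 (0.36 log units; beyond the scatter).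

Compound 4 `CCCSc1nc(N/N=C(\C)c2ccc(Br)cc2)c2nnn(Cc3ccccc3)c2n1` differs from compound 3 by bromo in place of hydroxy on an aromatic carbon. Going by the values given here, no measured step exchanges hydroxy for bromo on its own. Among the compounds with values here, the only analogue that carries a 4-chlorophenyl, compound 1, sits at the limit, and the move away from it, an at least 3.8-fold lower number from compound 1 to compound 3 (0.58 log units; beyond the scatter), ran toward lower numbers. Reversing toward a halogen-bearing ring is therefore expected to raise the number, by a modest amount. Compound 4 is expected to give about 40000 nM in this assay, between 15000 nM and 90000 nM. The expected step is a 2.4-fold higher number from compound 3 to compound 4 (0.38 log units; beyond the scatter).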

Compound 4, half-maximal inhibitory concentration: 6020 nM
Compound 4: middle estimate off by 6.6-fold (0.82 log units), on the high side; measured number outside the range, below it.
By their numbers in this assay, from the lowest: compound 4; then compound 3; then compound 2. At a limit, above all of these: compound 1.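

In this assay bromo in place of hydroxy, on an aromatic carbon para to a large group, gives a 2.8-fold lower number from compound 3 to compound 4 (0.44 log units; beyond the scatter) and so shows directly that 4-bromophenyl at this place carries a lower number than 4-hydroxyphenyl. The same ring also gives a 6.3-fold lower number from compound 2 to compound 4 (0.80 log units; beyond the scatter) and puts compound 4 lowest among the three compounds with measured numbers. The further step, an at least 10-fold lower number from compound 1 to compound 4 (1.02 log units; beyond the scatter) but changing more than the halogen alone, shows that the result for compound 1 says little about a halogen by itself, and it is only a floor, since compound 1 stands at a limit: the limit of > 64000 nM in this assay, at which 1 of the 4 values shown sits.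

Going by these compounds, whether chloro on the ring of compound 4 would match bromo remains open. So does whether an amine, a methoxy group or a carboxylic acid at this place would fall nearer to bromo or to hydroxy.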